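A few compounds are considered here, and "the series" means these few. Any claim that something is new, unique, unknown or untested is made for them only; others in the source may bear on it.

In a functional assay on the whole organism for antagonist activity, with Mus musculus as the target (a higher number here means that more compound is needed for the effect, a lower number that less compound is needed), compound 1 (`CN(C(=O)CNC(=O)CN1CCCCC1)c1ccc(Cl)cc1C(=O)c1ccccc1Cl`) gives 7.5 mg/kg, the highest of the three numbers in hand. Compound 2 (`CCCCCC(=O)NCC(=O)N(C)c1ccc(Cl)cc1C(=O)c1ccccc1Cl`) gives 1.9 mg/kg, and compound 3 (`NCC(=O)NCC(=O)Nc1ccc([N+](=O)[O-])cc1C(=O)c1ccccc1Cl`) gives 2.64 mg/kg. Compound 4 (`CC(=O)NCC(=O)N(C)c1ccc(Cl)cc1C(=O)c1ccccc1Cl`) is still unmeasured. Its change from compound 1 is hydrogen in place of piperidin-1-yl on a saturated chain carbon bound to a carbonyl carbon. Among the compounds with values here, one measured step bears on this: butyl in place of piperidin-1-yl at that same place gave a 3.9-fold lower number from compound 1 to compound 2 (0.60 log units; beyond the scatter). Within the data shown here, compound 3 differs in more than one place and offers no direct step. With hydrogen entering rather than butyl, a somewhat smaller step in the same direction is expected in this assay, an expected 2.1-fold lower number from compound 1 to compound 4 (0.33 log units; beyond the scatter). The estimate for compound 4 is 3.5 mg/kg, with an expected range of 1.2 mg/kg to 10 mg/kg.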

Compound 4, dose for half-maximal effect: 2.3 mg/kg
Beside the measured number, compound 4's estimate is 1.5-fold (0.18 log units) above it; low and high end bracket the measured number.
By their numbers in this assay, from the lowest: compounds 2, 4 and 3 (each within the scatter of the next); then compound 1.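

In this assay hydrogen entering for piperidin-1-yl gives a 3.3-fold lower number from compound 1 to compound 4 (0.51 log units; beyond the scatter) and so the lower number seen with butyl needs no added chain on this saturated chain carbon. Hydrogen against butyl reads a 1.2-fold higher number from compound 2 to compound 4 (0.08 log units; within the scatter) and the two groups are not told apart here, which leaves compound 1 alone with the higher number in this set. No evidence on the reason is at hand.

Open, on these data alone, is whether the ring or the nitrogen of piperidin-1-yl goes with that higher number, as cyclohexyl or diethylamino at this place could tell. Also open, as far as these compounds go, is how a chain longer than butyl reads here.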